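Working notes: from compound 3 to compound 4

The source may report more compounds than this note shows. Statements on the series, on what has been measured and on what is new or still open speak of the compounds shown alone.

Compound 1 `N#Cc1c(NNC(N)=S)nc(SCc2nc3ccccc3[nH]2)nc1-c1ccccc1`: 8.9 nM
Compound 2 `N#Cc1c(NC(N)=O)nc(SCc2nc3ccccc3[nH]2)nc1-c1ccccc1`: 4.54 nM
Compound 3 `CN1CCN(c2nc(SCc3nc4ccccc4[nH]3)nc(-c3ccccc3)c2C#N)CC1`: 2.4 nM

All three values come from a functional assay on K562 cells (Homo sapiens) for cytotoxicity, read by MTT assay, with a stated time of 3 days; a lower number here means a stronger inhibitor, a higher number a weaker inhibitor. Compound 3, at 2.4 nM, matches compound 2 within the scatter and differs clearly only from compound 1, with a 3.7-fold lower number from compound 1 to compound 3 (0.57 log units; beyond the scatter).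

Compound 4 `N#Cc1c(-c2ccccc2)nc(SCc2nc3ccccc3[nH]2)nc1N1CCN(S(=O)(=O)c2ccccc2[N+](=O)[O-])CC1` carries (2-nitrophenyl)sulfonyl in place of methyl on an amine nitrogen in a ring. Among the measured compounds shown here, no measured step touches that nitrogen. The nearest evidence is a 1.9-fold lower number from compound 2 to compound 3 (0.28 log units; within the scatter), and it concerns a different change, so it offers only a weak guide. Nothing firm beyond the scatter is expected, with a slight lean towards a higher number. The expected step is a 1.7-fold higher number from compound 3 to compound 4 (0.22 log units; within the scatter). For compound 4 the estimated value is 4 nM, with an expected range of 1.2 nM to 15 nM.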

Compound 4, half-maximal inhibitory concentration: 14.7 nM
Beside the measured number, compound 4's estimate is 3.7-fold (0.57 log units) below it; low and high end bracket the measured number.
By their numbers in this assay, from the lowest: compounds 3, 2, 1 and 4 (each within the scatter of the next, the first and the last beyond it).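

Among the compounds shown here, this is the first measured change on the amine nitrogen in the ring, and in this assay the exchange of methyl for (2-nitrophenyl)sulfonyl gives a 6.1-fold higher number from compound 3 to compound 4 (0.79 log units; beyond the scatter) with the core unchanged. The nitrogen therefore tolerates a group of 12 heavy atoms carrying an aromatic ring, with a cost beyond the scatter yet modest in size. No measurement available here explains this step.

From the compounds shown here alone, whether the step follows from the sulfonyl link or from the 2-nitrophenyl ring remains open. Methylsulfonyl, phenylsulfonyl or benzoyl on the same nitrogen would separate these two parts.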